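Ketone to Alcohol on a Side Chain, Tested Across Two Cores

This account rests on a few compounds, and the source may have more. Where it says the series, first, only, none or still open, it means among the compounds named here.

Compound 1 `CC[C@@H](C)[C@H](NC(=O)c1ccc(C(CC)(CC)c2ccc(OCC(=O)C(C)(C)C)c(C)c2)n1CC)C(=O)O`: 10 nM
Compound 2 `CC[C@@H](C)[C@H](NC(=O)c1ccc(C(CC)(CC)c2ccc(OCC(O)C(C)(C)C)c(C)c2)n1CC)C(=O)O`: 2.3 nM
Compound 3 `CCn1c(C(=O)OCc2ccccn2)ccc1C(CC)(CC)c1ccc(OCC(=O)C(C)(C)C)c(C)c1`: a limit of > 50000 nM

In an assay on HL-60 cells for agonist activity at vitamin D3 receptor (Homo sapiens), read by microscopy, with a stated time of 96 h (on this read-out higher numbers stand for an effect only at larger amounts of compound and lower numbers for an effect already at smaller amounts), compound 1 gives 10 nM. Compound 2 differs from it in one place, (1-hydroxy-2,2-dimethylpropyl in place of (tert-butyl)carbonyl on a saturated chain carbon bound to an oxygen on an aromatic ring), and in this assay compound 2 gives 2.3 nM. The step is a 4.3-fold lower number from compound 1 to compound 2 (0.64 log units; beyond the scatter).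

Compound 3 carries a different core, and the difference between the two cores is (pyridin-2-yl)methoxy in place of (1-carboxy-2-methylbutyl)amino on a carbonyl carbon. For compound 3 this assay reports only a limit, > 50000 nM. The step is an at least 5000-fold higher number from compound 1 to compound 3 (3.69 log units; beyond the scatter), and that rests on (the limit of > 50000 nM in this assay, at which 1 of the 3 values shown sits).

Compound 4 `CCn1c(C(=O)OCc2ccccn2)ccc1C(CC)(CC)c1ccc(OCC(O)C(C)(C)C)c(C)c1` has not yet been measured in this assay. It stands to compound 3 exactly as compound 2 stands to compound 1: 1-hydroxy-2,2-dimethylpropyl in place of (tert-butyl)carbonyl on a saturated chain carbon bound to an oxygen on an aromatic ring. The place of the change is the same in both pairs, so this is the same change made a second time, now on the core of compound 3.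

On the first core that change gave a 4.3-fold lower number from compound 1 to compound 2 (0.64 log units; beyond the scatter). For compound 4 the same size of step, a number no higher from compound 3 to compound 4 (the limit leaves the size open), is expected, resting on the step of a 4.3-fold lower number from compound 1 to compound 2 (0.64 log units; beyond the scatter) and on the limit given for compound 3. Since compound 3 shows only a limit, compound 4 is estimated at 50000 nM, within a range from 10000 nM to 200000 nM, and this assay is expected most likely to report a limit again rather than a number.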

Compound 4, half-maximal effective concentration: > 50000 nM
Compound 4: a limit, no number; the forecaster's own chance of this, stated with the estimate: 80%; the middle value sits exactly at the limit.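

In this assay compound 4 gives > 50000 nM, which is a limit of the assay and not a number: the limit of > 50000 nM in this assay, at which 2 of the 4 values shown sit. Both ends of the step on the core of compound 3 are therefore limits, so that step cannot be read, and nothing shows whether 1-hydroxy-2,2-dimethylpropyl in place of (tert-butyl)carbonyl repeats there the result seen on the core of compound 1, a 4.3-fold lower number from compound 1 to compound 2 (0.64 log units; beyond the scatter). What can be read is the difference between the cores with the alcohol in place, an at least 21000-fold higher number from compound 2 to compound 4 (4.33 log units; beyond the scatter), so the large gap between the two cores holds with either side chain, though its size cannot be compared between the two pairs: the same change on two cores in this assay, an at least 5000-fold higher number (3.69 log units; beyond the scatter) from compound 1 to compound 3 and an at least 21000-fold higher number (4.33 log units; beyond the scatter) from compound 2 to compound 4; the limit leaves it open whether they differ.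

The compounds shown leave open whether another group on the carbonyl carbon, such as a carboxylic acid or a smaller amino acid amide, would give a number rather than a limit on a second core, which is what a readable test of this change would need. They also leave open how an amine in place of the hydroxy group, or a longer chain in place of the tert-butyl end, would read in this assay.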